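Second chlorine on the phenyl ring and mouse inhibition

A few compounds are considered here, and "the series" means these few. Any claim that something is new, unique, unknown or untested is made for them only; others in the source may bear on it.

Three compounds have been measured in a functional assay on the whole organism for inhibition, with Mus musculus as the target, at a dose of 25 mg/kg by the oral route; a higher number here means more inhibition at the dose given (going by the name of the read-out), a lower number less inhibition:

Compound 1 `Clc1ccc(N2CCN(CCCOc3ccc4c(c3)CCC4)CC2)cc1` gives 43%.
Compound 2 `Clc1ccc(N2CCN(CCCCOc3ccc4c(c3)CCC4)CC2)cc1` gives 31%.
Compound 3 `Clc1cc(Cl)cc(N2CCN(CCCOc3ccc4c(c3)CCC4)CC2)c1` gives 0%.

Going by the values given here, the one change measured in isolation is 3,5-dichlorophenyl in place of 4-chlorophenyl on an amine nitrogen in a ring, and it produced a number 43 percentage points lower from compound 1 to compound 3 (beyond the scatter), the whole of the inhibition being lost. Compound 2 differs from compound 1 in the core, and that difference is not broken down here; what the two values show is that compound 2 sits below compound 1 and above compound 3.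

Compound 4 `Clc1cc(Cl)cc(N2CCN(CCCCOc3ccc4c(c3)CCC4)CC2)c1` has not yet been measured. It differs from compound 2 by 3,5-dichlorophenyl in place of 4-chlorophenyl on an amine nitrogen in a ring, the same change that separates compound 3 from compound 1. Since that change gave a number 43 percentage points lower from compound 1 to compound 3 (beyond the scatter), the expected step is a number 28 percentage points lower from compound 2 to compound 4 (beyond the scatter), taking compound 2 down to near nothing. For compound 4 the estimated inhibition is 3%, expected to lie between 0% and 15%.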

Compound 4, a percentage reported as inhibition, in the whole organism at one dose (the size of the read-out at that dose, not a potency): 0%
Beside the measured number, compound 4's estimate is 3 percentage points above it; measured number inside the range.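

In this assay, the change from 4-chlorophenyl to 3,5-dichlorophenyl carried over from one core to the other, with a number 31 percentage points lower from compound 2 to compound 4 (beyond the scatter), and the two steps agree in size: the same change on two cores in this assay, a number 43 percentage points lower (beyond the scatter) from compound 1 to compound 3 and a number 31 percentage points lower (beyond the scatter) from compound 2 to compound 4, 12 percentage points apart, within the scatter of two such steps

Compound 3 gives 0% and compound 4 gives 0%, so both steps end with no inhibition left to lose, and the read-out cannot show whether the change would cost more on one core than on the other. Two cores at a single dose do not show that the result holds on other cores, nor why the inhibition disappears.

Going by these compounds, it remains open how a phenyl ring bearing fluorine or a methoxy group in place of chlorine would behave. A longer chain on the same ring system is also an open case.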